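A few compounds are considered here, and "the series" means these few. Any claim that something is new, unique, unknown or untested is made for them only; others in the source may bear on it.

Measured so far in a functional assay on HCT-15 cells (Homo sapiens) for cytotoxicity, read by MTT assay, with a stated time of 2 days; on this read-out lower numbers stand for stronger inhibition and higher numbers for weaker inhibition:
- Compound 1 `CN(C)c1ccc2nc(-c3cccc4ccccc34)[nH]c(=O)c2c1`: 460 nM
- Compound 2 `Cc1ccc2nc(-c3cccc(C(F)(F)F)c3)[nH]c(=O)c2c1`: > 50000 nM (a limit of the assay, not a number)

Compound 2 stands at the limit of > 50000 nM in this assay, at which 1 of the 2 values shown sits. Its reading therefore marks where the assay stops and gives no exact potency.

Compound 3 `Cc1ccc2nc(-c3cccc(F)c3)[nH]c(=O)c2c1` keeps the rest of compound 2 and makes one change: fluoro in place of trifluoromethyl on an aromatic carbon, meta to a large group (fluoro in place of trifluoromethyl on an aromatic carbon).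

Within the data shown here, no measured pair shows what this swap does on its own. Compound 1, at 460 nM, differs from compound 2 in more than one place, so it cannot size the step. The starting point is therefore compound 2 with > 50000 nM, which is a limit. In this assay, only a modest shift toward stronger inhibition is expected, and the assay may well report a limit again. The expected change is an at least 1.6-fold lower number from compound 2 to compound 3 (0.22 log units; that floor lies within the scatter). For compound 3 the estimate is 30000 nM, with an expected range from 6000 nM to 50000 nM.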

Compound 3, half-maximal inhibitory concentration: > 50000 nM
Compound 3 gave a limit, no number; the forecaster's own chance of this, stated with the estimate: 55%; at least 1.6-fold (0.22 log units) between middle value and limit.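

In this assay compound 3 reads > 50000 nM, which is a limit and not a number. Compound 2 also sits at a limit, so no step can be read between compound 2 and compound 3: the limit of > 50000 nM in this assay, at which 2 of the 3 values shown sit.

The compounds shown leave open whether fluoro in place of trifluoromethyl changes the potency at all.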